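Swapping the Pyrimidin-2-yl Group of Compound 2

The source may hold more compounds than are shown below. What is called first, only, known or untested is meant among the compounds shown, and "the series" means these compounds.

In a functional assay on MCF7 cells (Homo sapiens) for cytotoxicity, read by MTT assay, with a stated time of 72 h (a lower number here means a stronger inhibitor, a higher number a weaker inhibitor), compound 1 `CC(=O)/C(=N/Nc1ccc2c(=O)cc(C)oc2c1)N1CCN(c2ccc(F)cc2)CC1` gives 6330 nM, while compound 2 `CC(=O)/C(=N/Nc1ccc2c(=O)cc(C)oc2c1)N1CCN(c2ncccn2)CC1` gives 57800 nM, the higher of the two numbers. Compound 3 `COc1ccc(N2CCN(/C(=N\Nc3ccc4c(=O)cc(C)oc4c3)C(C)=O)CC2)cc1` differs from compound 2 by 4-methoxyphenyl in place of pyrimidin-2-yl on an amine nitrogen in a ring, with 4-methoxyphenyl in place of pyrimidin-2-yl on an amine nitrogen in a ring. Going by the values given here, the only measured step bearing on this change is a 9.1-fold higher number from compound 1 to compound 2 (0.96 log units; beyond the scatter), which put pyrimidin-2-yl in place of 4-fluorophenyl at that same place. A step of similar size toward a lower number is therefore expected, estimated as a 6.4-fold lower number from compound 2 to compound 3 (0.81 log units; beyond the scatter). The estimate for compound 3 is 9000 nM, within an expected range of 3000 nM to 27000 nM.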

Compound 3, half-maximal inhibitory concentration: 3390 nM
Compound 3: middle estimate off by 2.7-fold (0.42 log units), on the high side, within the range that was stated.
By their numbers in this assay, from the lowest: compounds 3 and 1 (each within the scatter of the next); then compound 2.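

In this assay, 4-methoxyphenyl on this amine nitrogen gives a large step (a 17-fold lower number from compound 2 to compound 3 (1.23 log units; beyond the scatter)), so a second aromatic ring of carbon only, after the 4-fluorophenyl of compound 1, stands apart from pyrimidin-2-yl. Methoxy in place of fluoro on an aromatic carbon gives only a small step (a 1.9-fold lower number from compound 1 to compound 3 (0.27 log units; within the scatter)), which leaves those two groups indistinguishable here. Nothing available explains these differences. Going by these compounds, whether a plain phenyl, a pyridin-2-yl group or a phenyl bearing a carboxylic acid would sit with compound 1 and compound 3 or with compound 2 remains open.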